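This account rests on a few compounds, and the source may have more. Where it says the series, first, only, none or still open, it means among the compounds named here.

Measured compounds:
- Compound 1 `Cc1cc(-c2cc(Cl)cc(C)c2/C=C/[C@@H]2C[C@@H](O)CC(=O)O2)ccc1F`: 6 nM
- Compound 2 `O=C1C[C@H](O)C[C@@H](/C=C/c2c(Cl)cc(Cl)cc2-c2ccccc2)O1`: 80 nM

Of the compounds shown here, two have so far been tested in an assay for inhibition of 3-hydroxy-3-methylglutaryl-coenzyme A reductase (Rattus norvegicus); on this read-out higher numbers stand for weaker inhibition and lower numbers for stronger inhibition. In this assay compound 1 gives 6 nM, while compound 2 gives 80 nM, the higher of the two numbers, and the gap between them lies beyond the usual scatter of repeated measurements, so compound 2 is the weaker inhibitor of the pair. Compound 3 `O=C1C[C@H](O)C[C@@H](/C=C/c2c(Cl)cc(Cl)cc2CCc2ccccc2)O1` has not yet been measured. It differs from compound 2 in a single place: phenethyl in place of phenyl on an aromatic carbon. The change sits on an aromatic carbon of a six-membered aromatic ring of carbon only, ortho to a large group and meta to two chloro groups. Going by the values given here, no measured pair shows this particular change, so its effect can only be guessed from compound 2 alone. The step from compound 2 to compound 3 is expected to be a 3.1-fold higher number from compound 2 to compound 3 (0.49 log units; beyond the scatter), a moderate rise in the number toward weaker inhibition, somewhat beyond the scatter. Compound 3 is therefore expected to give about 250 nM, with a plausible range from 80 nM to 800 nM.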

Compound 3, half-maximal inhibitory concentration: 430 nM
Estimate against measurement, compound 3: 1.7-fold (0.24 log units) below; the measured number falls inside the stated range.
By their numbers in this assay, from the lowest: compound 1; then compound 2; then compound 3.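

In this assay, phenethyl in place of phenyl on this aromatic carbon gives a 5.4-fold higher number from compound 2 to compound 3 (0.73 log units; beyond the scatter) and so shows that inhibition responds to what is attached at this position, with the phenethyl compound being the weaker inhibitor of this pair. The two groups share one six-membered aromatic ring of carbon only, and neither has hydrogen-bond donors, hydrogen-bond acceptors or a net charge, so this pair differs in size and reach: phenethyl has 8 heavy atoms and phenyl has 6, all of them carbon. No measurement available here explains why the number rises.

The compounds shown leave open how benzyl or a longer chain would compare at this position, and so whether inhibition keeps weakening as the group grows. They also leave open how an amine or a carboxylic acid on the end of such a chain would behave, and whether the same change would have a similar effect on the core of compound 1.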